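Adding Chlorine to the Benzoyl Ring of Compound 2

This account rests on a few compounds, and the source may have more. Where it says the series, first, only, none or still open, it means among the compounds named here.

Compound 2 `O=C(Nc1ccccc1C(F)(F)F)C1CCc2ccccc2N1C(=O)c1ccccc1` carries a benzoyl group on the ring nitrogen of the shared core. Among the measured compounds shown here, in a functional assay on PC-3 cells (Homo sapiens) for cytotoxicity, read by sulforhodamine B assay, with a stated time of 72 h (a higher number here means a weaker inhibitor of growth, a lower number a stronger inhibitor of growth), compound 2 gives 5560 nM, the only plain number among the two values shown. Its companion is compound 1 `CCCC(=O)N1c2ccccc2CCC1C(=O)Nc1ccccc1C(F)(F)F`, which has a propyl group in place of the phenyl on that carbonyl carbon. In this assay compound 1 gives only a limit, > 70000 nM. For the measured compounds named here, the step of an at least 12-fold lower number from compound 1 to compound 2 (1.10 log units; beyond the scatter) is the single measured step, and it rests on (the limit of > 70000 nM in this assay, at which 1 of the 2 values shown sits), so its true size is known only as large.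

Compound 3 `O=C(Nc1ccccc1C(F)(F)F)C1CCc2ccccc2N1C(=O)c1ccc(Cl)cc1` differs from compound 2 by chloro in place of hydrogen on an aromatic carbon. Going by the values given here, no measured step touches the benzoyl ring itself; the one step known, from propyl to phenyl, alters a different part of the molecule and offers no direct guide to a chloro on the aromatic ring. The expectation for compound 3 is therefore a step within the usual scatter, a 1.2-fold lower number from compound 2 to compound 3 (0.09 log units; within the scatter), held with wide uncertainty. Compound 3 is estimated at 4500 nM, with a range from 1500 nM to 15000 nM.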

Compound 3, concentration for 50% growth inhibition: 786 nM
Estimate against measurement, compound 3: 5.7-fold (0.76 log units) above, outside the stated range (below it).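

The earlier step swapped the whole group on the carbonyl carbon, whereas this one shows that the benzoyl ring itself responds to a very small change: a single chloro, para to a large group, gives a 7.1-fold lower number from compound 2 to compound 3 (0.85 log units; beyond the scatter) in this assay. Among the compounds shown here, both ends of this step are plain numbers, so its size is known and does not merely have a bound, which makes it the firmest reading of the series so far. Seen from the other end, 4-chlorophenyl in place of propyl gives an at least 89-fold lower number from compound 1 to compound 3 (1.94 log units; beyond the scatter), but that size is only a bound and the true step could be larger, as it rests on a limit: the limit of > 70000 nM in this assay, at which 1 of the 3 values shown sits.

For the compounds shown here, with only one substituent on this ring, it remains open whether the change depends on chlorine in particular or whether another group, such as fluoro, methyl or methoxy, would do the same at this place. On these data alone, it also remains open whether a chloro placed elsewhere on the ring would match this step, and how far the result holds beyond this one cell line.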